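The compounds below may be only part of what the source reports. "The series", "measured", "known", "first", "only" and "open" are said of these compounds alone.

Compound 1 `O=C(COc1ccc(C(=O)/C=C/c2ccc(Cl)cc2Cl)cc1)N[C@H]1CCOC1=O` carries a 2,4-dichlorophenyl group on its unsaturated chain. Going by the values given here, in a functional assay on PC-3 cells (Homo sapiens) for antiproliferative activity, read by MTT assay, with a stated time of 72 h (a higher number here means a weaker inhibitor, a lower number a stronger inhibitor), compound 1 gives 8040 nM, which is the only numerical value among the two compounds measured so far. Compound 2 `Cc1ccc(C(C)C)c(OCCSC(=S)N[C@H]2CCOC2=O)c1`, built on a different skeleton, gives > 64000 nM in this assay; that is a limit of the assay rather than a number. Compound 3 `CC(C)(C)c1ccc(/C=C/C(=O)c2ccc(OCC(=O)N[C@H]3CCOC3=O)cc2)cc1` has not yet been tested. It differs from compound 1 in one place: 4-(tert-butyl)phenyl in place of 2,4-dichlorophenyl on a double-bonded chain carbon bound to a double-bonded chain carbon. Among the compounds with values here, no measured pair shows what this kind of aryl exchange does in this assay, so the expectation rests on compound 1 alone. The exchange is expected to move the result only modestly, likely not far beyond the usual scatter, and the estimated step is a 1.2-fold higher number from compound 1 to compound 3 (0.09 log units; within the scatter). Compound 3 is therefore expected to give about 10000 nM, with a range from 3000 nM to 32000 nM.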

Compound 3, half-maximal inhibitory concentration: 10600 nM
The estimate for compound 3 lay 1.1-fold (0.03 log units) below the measured number; the range from low to high includes it.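

In this assay, the exchange of 2,4-dichlorophenyl for 4-(tert-butyl)phenyl on a double-bonded chain carbon bound to a double-bonded chain carbon gives a 1.3-fold higher number from compound 1 to compound 3 (0.12 log units; within the scatter). This first measured pair shows that an aryl group carrying only carbon can stand at this place in the shared core, in lieu of one carrying chlorine, without a difference that can be told from the scatter. Compound 2 adds no comparison, as its entry is a limit of the assay and not a number: the limit of > 64000 nM in this assay, at which 1 of the 3 values shown sits.

One pair cannot say whether this place stays as indifferent to an aryl group bearing an amine or a carboxylic acid. Nor do the compounds shown tell whether a longer chain elsewhere on the shared core would move the number.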